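The source may hold more compounds than are shown below. What is called first, only, known or untested is meant among the compounds shown, and "the series" means these compounds.

The three measured compounds share one core and differ only in the aryl group attached to one aromatic carbon. Compound 1 `Cc1nc2c3ccccc3ccc2c2nc3c(ccc4ccccc43)c(-c3cccnc3)c12` carries pyridin-3-yl there, compound 2 `Cc1nc2c3ccccc3ccc2c2nc3c(ccc4ccccc43)c(-c3nccnc3N)c12` carries 3-aminopyrazin-2-yl, and compound 3 `Cc1nc2c3ccccc3ccc2c2nc3c(ccc4ccccc43)c(-c3cccc4ccccc34)c12` carries naphthalen-1-yl. In a functional assay, read by spectrophotometry, with a stated time of 30 min (a lower number here means a stronger inhibitor, a higher number a weaker inhibitor), compound 1 gives 98.2 ug/mL, compound 2 gives 81.7 ug/mL, and compound 3 gives 111 ug/mL. Compound 3 sits at the high end of these three numbers, but the separations are small: a 1.1-fold higher number from compound 1 to compound 3 (0.05 log units; within the scatter) and a 1.4-fold higher number from compound 2 to compound 3 (0.13 log units; within the scatter), so none of the three can be called the stronger or weaker inhibitor.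

Compound 4 `Cc1nc2c3ccccc3ccc2c2nc3c(ccc4ccccc43)c(-c3cc([N+](=O)[O-])ccc3N)c12` continues the series with a single change: 2-amino-5-nitrophenyl in place of naphthalen-1-yl on an aromatic carbon. Among the compounds with values here, the steps that bear on this are the two that already traded naphthalen-1-yl against a ring bearing nitrogen, that is a 1.1-fold higher number from compound 1 to compound 3 (0.05 log units; within the scatter) and a 1.4-fold higher number from compound 2 to compound 3 (0.13 log units; within the scatter), and the swap between the two nitrogen-bearing rings, a 1.2-fold lower number from compound 1 to compound 2 (0.08 log units; within the scatter). All three lie within the scatter, so the replacement of the two-ring group by another single ring carrying an amino and a nitro group is expected to move the number little, if at all.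

Compound 4 is therefore estimated at 95 ug/mL, with a range from 50 ug/mL to 190 ug/mL. The estimated change is a 1.2-fold lower number from compound 3 to compound 4 (0.07 log units; within the scatter), which is not expected to exceed the scatter.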

Compound 4, half-maximal inhibitory concentration: 93.1 ug/mL
Compound 4: middle estimate off by 1.0-fold (0.01 log units), on the high side, within the range that was stated.
By their numbers in this assay, from the lowest: compounds 2, 4, 1 and 3 (each within the scatter of the next).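

Swapping naphthalen-1-yl, which is carbon only, for 2-amino-5-nitrophenyl brings in nitrogen and oxygen atoms, a hydrogen-bond donor and hydrogen-bond acceptors while keeping the same count of heavy atoms, yet this assay gives only a 1.2-fold lower number from compound 3 to compound 4 (0.08 log units; within the scatter). The new group also stays level with the two nitrogen-bearing rings, with a 1.1-fold higher number from compound 2 to compound 4 (0.06 log units; within the scatter) and a 1.1-fold lower number from compound 1 to compound 4 (0.02 log units; within the scatter), so this position, opposite the ring nitrogen, has now held four different aromatic groups with no readable separation among them, even when the entering group carries both an amino and a nitro group. Nothing available accounts for this flat result.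

All four groups are aromatic rings, so the compounds leave open what a group of another kind at this carbon would do, such as a morpholine, a carboxylic acid or a longer alkyl chain. They also leave open whether any change to the shared core itself, such as replacing its methyl group with an amine, would move the number beyond the scatter.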